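Methyl-to-bromo swap on two indole-fused diterpenoid cores

A few compounds are considered here, and "the series" means these few. Any claim that something is new, unique, unknown or untested is made for them only; others in the source may bear on it.

Of the compounds shown here, three have so far been tested in a functional assay on T47D cells (Homo sapiens) for inhibition, read by sulforhodamine B assay, with a stated time of 48 h; a lower number here means a stronger inhibitor of growth, a higher number a weaker inhibitor of growth. Compound 1 `COC(=O)[C@@]1(C)CCC=C2[C@@H]1CC[C@@H](C)[C@]2(C)Cc1c(C)[nH]c2c(C)cccc12` gives 19000 nM in this assay. Compound 2 `COC(=O)[C@@]1(C)CCC=C2[C@@H]1CC[C@@H](C)[C@]2(C)Cc1c(C)[nH]c2c(Br)cccc12` differs from compound 1 by a single change, (bromo in place of methyl on an aromatic carbon); in this assay compound 2 gives 31000 nM, and the step of a 1.6-fold higher number from compound 1 to compound 2 (0.21 log units; within the scatter) is small. Compound 3 `COC(=O)[C@@]1(C)CC[C@@H]2C3=C1CC[C@@H](C)[C@]3(C)Cc1c2[nH]c2ccc(C)cc12` is built on a different core, and the difference between the two cores is not broken down here; in this assay compound 3 gives 16000 nM, which lies within the scatter of the numbers for compound 1 and compound 2, so no order among the three can be read from them.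

Compound 4 `COC(=O)[C@@]1(C)CC[C@@H]2C3=C1CC[C@@H](C)[C@]3(C)Cc1c2[nH]c2ccc(Br)cc12` is not yet measured. It stands to compound 3 as compound 2 stands to compound 1: bromo in place of methyl on an aromatic carbon. The surroundings are not identical, since in compound 3 the ring is part of a fused or bridged system of five rings and the position is meta to a fused ring and para to a fused ring, whereas in compound 1 the ring belongs to a fused or bridged system of two rings and the position is ortho to a fused ring and meta to a fused ring; the two changes are therefore the same kind of change rather than the same change. Within the data shown here, for compound 4 the expected step in this assay is a 1.5-fold higher number from compound 3 to compound 4 (0.18 log units; within the scatter), set beside the earlier one because the only guide is a 1.6-fold higher number from compound 1 to compound 2 (0.21 log units; within the scatter), which stayed within the scatter. The estimated number for compound 4 in this assay is 24000 nM, with a range from 10000 nM to 60000 nM.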

Compound 4, concentration for 50% growth inhibition: 21000 nM
Compound 4: middle estimate off by 1.1-fold (0.06 log units), on the high side; the measured number falls inside the stated range.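

On the core of compound 3, bromo in place of methyl gives a 1.3-fold higher number from compound 3 to compound 4 (0.12 log units; within the scatter) in this assay and is thus a small step, as it was on the core of compound 1. The two steps do not differ from each other: the same change on two cores in this assay, a 1.6-fold higher number (0.21 log units; within the scatter) from compound 1 to compound 2 and a 1.3-fold higher number (0.12 log units; within the scatter) from compound 3 to compound 4, 1.2-fold (0.09 log units) apart, within the scatter of two such steps. This shows that for these two pairs the swap carries from one core to the other in the limited sense that neither step rises above the scatter, but it does not show that the swap has any effect of its own on growth inhibition, and two pairs, with the group placed differently on each core, cannot establish a rule for the series.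

Only methyl and bromo are shown on these aromatic carbons, so it remains open whether an amine or a longer chain at the same places would give a step beyond the scatter on either core, or whether such a step would then carry from one core to the other. All four compounds also keep the same methyl ester, which leaves open how a carboxylic acid in its place would read on each core.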